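Compound 3 to compound 4: anilino replaces pyridin-4-yl

A few compounds are considered here, and "the series" means these few. Any claim that something is new, unique, unknown or untested is made for them only; others in the source may bear on it.

Measured so far in a physicochemical assay for solubility (on this read-out higher numbers stand for higher solubility and lower numbers for lower solubility), for three compounds:
compound 1 `CC(C)C(=O)N1CCC[C@H]1C(=O)N1CCC(NS(=O)(=O)c2cc(S(=O)(=O)c3ccccc3)ccc2C(F)(F)F)CC1` gives 100000 nM
compound 2 `CN(C)CC(=O)N1CCC[C@H]1C(=O)N1CCC(NS(=O)(=O)c2cc(S(=O)(=O)c3ccccc3)ccc2C(F)(F)F)CC1` gives 100000 nM
compound 3 `O=C([C@@H]1CCCN1C(=O)c1ccncc1)N1CCC(NS(=O)(=O)c2cc(S(=O)(=O)c3ccccc3)ccc2C(F)(F)F)CC1` gives 100000 nM

Among the compounds with values here, compound 3 stands level with compound 1 and compound 2, so no member of the set is separated from the others. The next structure is compound 4 `O=C([C@@H]1CCCN1C(=O)Nc1ccccc1)N1CCC(NS(=O)(=O)c2cc(S(=O)(=O)c3ccccc3)ccc2C(F)(F)F)CC1`, and the difference from compound 3 reads anilino in place of pyridin-4-yl on a carbonyl carbon in the counted terms. In words, anilino takes the place of pyridin-4-yl on a carbonyl carbon, the place varied across the measured compounds.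

Three measured steps at this place bear on the change. They show no change at the digits printed from compound 1 to compound 3 (within the scatter) and no change at the digits printed from compound 2 to compound 3 (within the scatter) and also no change at the digits printed from compound 1 to compound 2 (within the scatter) in the same series. Within the data shown here, none of the measured compounds carries anilino at this place, so the expectation rests on those steps alone and remains weakly supported.

The expected outcome is a 1.1-fold lower number from compound 3 to compound 4 (0.05 log units; within the scatter) as an estimate, with no step beyond the scatter expected in either direction. Compound 4 is expected at 90000 nM with an estimated range from 40000 nM to 100000 nM for the coming measurement.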

Compound 4, solubility: 25000 nM
The estimate for compound 4 lay 3.6-fold (0.56 log units) above the measured number; the whole stated range lies above it.
By their numbers in this assay, from the lowest: compound 4; then compounds 1, 2 and 3 (each within the scatter of the next).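

In this assay, this place on a carbonyl carbon had shown no separation among isopropyl, (dimethylamino)methyl and pyridin-4-yl, but anilino now gives a 4.0-fold lower number from compound 3 to compound 4 (0.60 log units; beyond the scatter), along with a 4.0-fold lower number from compound 2 to compound 4 (0.60 log units; beyond the scatter) and a 4.0-fold lower number from compound 1 to compound 4 (0.60 log units; beyond the scatter). The read-out therefore does respond to a change at this place, at least for this one group: phenylcarbamoyl replaces (pyridin-4-yl)carbonyl, with a hydrogen-bond donor entering and a hydrogen-bond acceptor leaving. No measurement at hand gives a cause for this step.

From the compounds shown here alone, it remains open whether the step follows the anilino nitrogen with its hydrogen or the all-carbon aromatic ring; a plain phenyl or a methyl(phenyl)amino group at this place would separate the two. Also open, going by these compounds, is how a carboxylic acid or a longer chain ending in an amine would read here.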